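Aryl sulfonate series: alkyl homologation on the amide side

The compounds below may be only part of what the source reports. "The series", "measured", "known", "first", "only" and "open" are said of these compounds alone.

Measured so far:
compound 1, `CC(C)C(=O)Nc1ccc(S(=O)(=O)Oc2ccccc2I)cc1`: 13000 nM
compound 2, `CC(C)(C)C(=O)Nc1ccc(S(=O)(=O)Oc2ccccc2I)cc1`: 8300 nM
compound 3, `CCNC(=O)Nc1ccc(S(=O)(=O)Oc2ccccc2C(C)C)cc1`: 4700 nM

All three were run in a functional assay on M21 cells (Homo sapiens) for antiproliferative activity, read by sulforhodamine B assay, with a stated time of 48 h; a lower number here means a stronger inhibitor, a higher number a weaker inhibitor. Compound 1 and compound 2 share a core and differ by methyl in place of hydrogen on a saturated chain carbon bound to a carbonyl carbon and two saturated chain carbons; this gave a 1.6-fold lower number from compound 1 to compound 2 (0.19 log units; within the scatter). Compound 3 carries a different core; the difference between the two cores is not broken down here. Compound 3 has the lowest of the three numbers, and its gap to compound 2 lies within the scatter.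

Compound 4, `CCCNC(=O)Nc1ccc(S(=O)(=O)Oc2ccccc2C(C)C)cc1`, is not yet measured. It differs from compound 3 by methyl in place of hydrogen on a saturated chain carbon, two bonds along the chain from an amide-type nitrogen. This is the same kind of change as that between compound 1 and compound 2, not the same one: there the carbon was bound to a carbonyl carbon and two saturated chain carbons, here it sits two bonds along the chain from an amide-type nitrogen. A small step, a 1.3-fold lower number from compound 3 to compound 4 (0.13 log units; within the scatter), is expected because a 1.6-fold lower number from compound 1 to compound 2 (0.19 log units; within the scatter) stayed within the scatter. Compound 4 is therefore estimated at 3500 nM, with a range from 1500 nM to 8000 nM.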

Compound 4, half-maximal inhibitory concentration: 5100 nM
Compound 4: middle estimate off by 1.5-fold (0.16 log units), on the low side; measured number inside the range.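

Going from ethylamino to propylamino gives a 1.1-fold higher number from compound 3 to compound 4 (0.04 log units; within the scatter) in this assay. Set beside the earlier methyl-for-hydrogen step, the result gives no sign that the two cores respond differently: the same change on two cores in this assay, a 1.6-fold lower number (0.19 log units; within the scatter) from compound 1 to compound 2 and a 1.1-fold higher number (0.04 log units; within the scatter) from compound 3 to compound 4, 1.7-fold (0.23 log units) apart, within the scatter of two such steps. This does not establish that the change transfers between cores, as both steps are small, the carbon that changes lies in a different setting on each core, and each core is represented by a single pair.

Open, on these data alone, is whether a longer chain such as butylamino, or a chain ending in a carboxylic acid or an amine, would give a step beyond the scatter. Also open, as far as these compounds go, is how ethylamino and propylamino would read on the core of compound 1.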